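A few compounds are considered here, and "the series" means these few. Any claim that something is new, unique, unknown or untested is made for them only; others in the source may bear on it.

In an ADME assay on Raji cells (Homo sapiens) for cytotoxicity, with a stated time of 72 h (a higher number here means that more compound is needed for the effect, a lower number that less compound is needed), compound 1 (`Cc1cc(NC(=O)Nc2ccc(C)c(Cl)c2)c2ccccc2n1`) gives > 25000 nM as a limit of the assay, not a number. Compound 2 (`CC(=O)c1ccc(NC(=O)Nc2cc(C)nc3ccccc23)cc1`) gives > 25000 nM as a limit too. Compound 3 (`Cc1ccc(NC(=O)Nc2cc(C)nc3ccccc23)cc1`) gives > 25000 nM as a limit as well. Compound 3 therefore sits with the others at the limit of > 25000 nM in this assay, at which 3 of the 3 values shown sit, and has no exact number of its own.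

Compound 4 (`Cc1cc(NC(=O)Nc2cccnc2)c2ccccc2n1`) is still unmeasured. It carries pyridin-3-yl in place of 4-methylphenyl on an amide-type nitrogen. The measured steps a step that the two limits leave unreadable from compound 1 to compound 3 and a step that the two limits leave unreadable from compound 2 to compound 3 both alter the ring that compound 4 swaps out, yet neither has a readable size. Compound 3 offers only its limit of > 25000 nM as an anchor, so no step beyond the scatter is expected in this assay, and another limit is the likeliest report. The expected step, a number no higher from compound 3 to compound 4 (the limit leaves the size open), is only an estimate. For compound 4 the estimate is 25000 nM with an expected range from 12000 nM to 50000 nM as the likely span.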

Compound 4, half-maximal effective concentration: > 25000 nM
Compound 4: no number, only a limit (the forecaster's own chance of this, stated with the estimate: 85%); the middle value sits exactly at the limit.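

Among these compounds, compound 4, like compound 3, reports only a limit, so no step between them can be read, and the same holds for the earlier steps among compounds 1, 2 and 3. All the results in this assay share one ceiling: the limit of > 25000 nM in this assay, at which 4 of the 4 values shown sit.

The compounds shown leave open how much compound any of them would need for the effect, and whether swapping 4-methylphenyl for pyridin-3-yl changes that amount at all.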